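Triazole aryl to alkyl swap in the furanone series

This account rests on a few compounds, and the source may have more. Where it says the series, first, only, none or still open, it means among the compounds named here.

Measured so far:
compound 1 `O=C1O/C(=C\Cn2cc(-c3ccc(Br)cc3)nn2)C(OCc2ccccc2)=C1OCc1ccccc1`: > 100000 nM
compound 2 `O=C1O[C@H]([C@@H](O)Cn2cc(-c3ccc(Br)cc3)nn2)C(OCc2ccccc2)=C1OCc1ccccc1`: 5830 nM

Among the compounds with values here, in a functional assay on CFPAC-1 cells (Homo sapiens) for antiproliferative activity, read by MTT assay, with a stated time of 72 h (on this read-out higher numbers stand for weaker inhibition and lower numbers for stronger inhibition), compound 2 gives 5830 nM, the only number among the values shown. Compound 1 reaches only a limit of the assay, > 100000 nM (the limit of > 100000 nM in this assay, at which 1 of the 2 values shown sits). Compound 3 `CCCCc1cn(C[C@H](O)[C@H]2OC(=O)C(OCc3ccccc3)=C2OCc2ccccc2)nn1` differs from compound 2 by butyl in place of 4-bromophenyl on an aromatic carbon. Within the data shown here, no step between two measured compounds exists for this change, so its size is uncertain; a modest weakening, near the edge of the scatter, is expected. Compound 3 is estimated at 12000 nM, between 3000 nM and 60000 nM. The expected step is a 2.1-fold higher number from compound 2 to compound 3 (0.31 log units; beyond the scatter).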

Compound 3, half-maximal inhibitory concentration: 73200 nM
The estimate for compound 3 lay 6.1-fold (0.79 log units) below the measured number, outside the stated range (above it).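

In this assay, within the data shown here, butyl in place of 4-bromophenyl on this aromatic carbon gives a 13-fold higher number from compound 2 to compound 3 (1.10 log units; beyond the scatter), the first measured step at this place. The group here therefore matters to the read-out, and this ring-free chain does not hold the level of compound 2. Little room remains above compound 3 before the read-out ends at a limit: the limit of > 100000 nM in this assay, at which 1 of the 3 values shown sits.

On these data alone, whether the loss goes with the ring or with the bromine stays open; plain phenyl would separate the two. A longer chain, or a butyl chain ending in an amine, also remains untested among the compounds shown.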